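Ethoxy for fluoro on the fused core in Hep 3B2 cells

The compounds below may be only part of what the source reports. "The series", "measured", "known", "first", "only" and "open" are said of these compounds alone.

The study concerns two measured quinoline-type amides and compound 3, which awaits measurement. Compound 2 `Cc1c(C(=O)Nc2c(F)cc(-c3cccc(F)c3)cc2F)nc2ccc(F)cc2c1C(=O)O` and compound 1 `CCOc1ccc2nc(C(=O)Nc3c(F)cc(-c4cccc(F)c4)cc3F)c(C)c(O)c2c1` were both tested in a functional assay on Hep 3B2 cells (Homo sapiens) for antiproliferative activity, read by MTT assay, with a stated time of 24 h, tested at 0.14 ug/mL; on this read-out lower numbers stand for a weaker effect and higher numbers for a stronger effect at the one concentration tested. Compound 2 gives 0.65%, the higher of the two numbers recorded; compound 1 gives 0.01%, and the gap between the two lies within the scatter, so neither can be said to act more strongly than the other. Both numbers sit close to zero, so neither compound shows a measurable effect at the single concentration used.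

Compound 3 `CCOc1ccc2nc(C(=O)Nc3c(F)cc(-c4cccc(F)c4)cc3F)c(C)c(C(=O)O)c2c1` is the unmeasured compound. Its structure differs from compound 2 in one place: ethoxy in place of fluoro on an aromatic carbon. Among the compounds with values here, with only two measured compounds and no step between them recorded, there is nothing in the data that points to a change beyond the scatter in this assay for this replacement. Compound 3 is therefore expected to return a read-out near zero, at 0.5% with a range of 0% to 8%, so that the estimated step of a number 0.2 percentage points lower from compound 2 to compound 3 (within the scatter) stays within the scatter.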

Compound 3, a percentage reported as inhibition, at one concentration (the size of the read-out at that concentration, not a potency): 2.06%
For compound 3 the middle estimate is 1.6 percentage points below the measured one; the measured number falls inside the stated range.
By their numbers in this assay, from the lowest: compounds 1, 2 and 3 (each within the scatter of the next).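

In this assay, within the data shown here, the change of ethoxy in place of fluoro on an aromatic carbon, meta to a fused ring and para to a fused ring, gives a number 1.4 percentage points higher from compound 2 to compound 3 (within the scatter) and so supplies the first reading at this position: the ring carbon takes ethoxy, with 3 heavy atoms against the 1 of fluoro, without a shift that can be told from noise. The second replacement, carboxy in place of hydroxy on an aromatic carbon, gives a number 2.1 percentage points higher from compound 1 to compound 3 (within the scatter) and is just as unresolved, so neither change separates the compounds at the one concentration tested. No measurement on these compounds offers an explanation for either step.

Still open, from the compounds shown here alone, is whether a longer chain such as butoxy, or an amine, on that same aromatic carbon would carry the read-out beyond the scatter. Also open, going by these compounds, is whether ethoxy and fluoro would part at a concentration where the read-out stands well clear of zero, since all three numbers here lie too close to it to rank the compounds.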